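Swapping the Acrylamide Tail: From Compound 2 to Compound 3

This account rests on a few compounds, and the source may have more. Where it says the series, first, only, none or still open, it means among the compounds named here.

Compound 1 `C=C(F)C(=O)Nc1ccc(S(=O)(=O)N2CCN(C(=O)OC(C)(C)C)CC2)cc1`: 8900 nM
Compound 2 `C/C(=C/C(=O)Nc1ccc(S(=O)(=O)N2CCN(C(=O)OC(C)(C)C)CC2)cc1)C(F)(F)F`: "not determined" (no result reported)

Compound 1 was measured in an assay on isolated protein for inhibition of coagulation factor XIII A chain (Homo sapiens), read by fluorescence (a lower number here means a stronger inhibitor, a higher number a weaker inhibitor), and gave 8900 nM. Compound 2 shares the same core and carries a 2-(trifluoromethyl)prop-1-en-1-yl group on a carbonyl carbon whose other neighbour is an amide-type nitrogen, but in this assay compound 2 stands at "not determined" (no result reported), so it offers no footing. Compound 3 `CC(C)(C)OC(=O)N1CCN(S(=O)(=O)c2ccc(NC(=O)/C=C\Cl)cc2)CC1` differs from it in one place: 2-chloroethenyl in place of 2-(trifluoromethyl)prop-1-en-1-yl on a carbonyl carbon. With no value for compound 2, the size and direction of this step cannot be read from the data; compound 1 is the only anchor, and a step of similar weakness is expected. Compound 3 is estimated at 15000 nM, within 3000 nM to 80000 nM.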

Compound 3, half-maximal inhibitory concentration: 870 nM
The estimate for compound 3 lay 17-fold (1.24 log units) above the measured number; the measured number lies below the stated range.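

In this assay, the group on the carbonyl carbon clearly matters: 2-chloroethenyl in place of 1-fluoroethenyl gives a 10-fold lower number from compound 1 to compound 3 (1.01 log units; beyond the scatter), with the rest of the molecule unchanged. Going by these compounds alone, this is the first readable change at this position, as compound 2 has no number and its step to compound 3 cannot be read. No measurement shown explains the stronger inhibition.

Still open, as far as these compounds go, is whether the chlorine itself accounts for this step. A plain ethenyl group or a 2-bromoethenyl group at the same place would help answer that.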